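The source may hold more compounds than are shown below. What is called first, only, known or untested is meant among the compounds shown, and "the series" means these compounds.

Measured so far:
- compound 1, `Cc1nc(-c2ccccc2)c(C(=O)N2CCN(c3cccc(Cl)c3Cl)CC2)o1`: 133 nM
- compound 2, `CCc1nc(-c2ccc(C(C)C)cc2)c(C(=O)N2CCN(c3cccc(OC)c3)CC2)o1`: 887 nM

Of the compounds shown here, two have been measured in a functional assay on HL-60 cells (Homo sapiens) for inhibition, read by MTT assay, with a stated time of 72 h; a lower number here means a stronger inhibitor, a higher number a weaker inhibitor. Compound 1 gives 133 nM and stands as the lower of the two numbers; compound 2 gives 887 nM, a gap beyond the usual scatter. Among the compounds with values here, compound 2 differs from compound 1 in more than one place, so no single-point step can be drawn between them.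

Compound 3, `CC(=O)Nc1cccc(N2CCN(C(=O)c3oc(C)nc3-c3ccccc3)CC2)c1`, is not yet measured. It differs from compound 1 in one place only: 3-acetamidophenyl in place of 2,3-dichlorophenyl on an amine nitrogen in a ring. The shared core of compound 1 and the amide link to the six-membered ring with two nitrogens are kept; only the aryl group on that ring nitrogen changes.

Within the data shown here, no measured step in this assay isolates this position, so the expectation rests on the structural change alone. A shift to a higher number than compound 1 is expected, of moderate size, though a result within the scatter of compound 1 cannot be excluded. The estimated step from compound 1 to compound 3 is a 3.0-fold higher number from compound 1 to compound 3 (0.48 log units; beyond the scatter). Compound 3 is therefore expected to give 400 nM in this assay, within the range 120 nM to 1500 nM.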

Compound 3, half-maximal inhibitory concentration: 329 nM
Compound 3: middle estimate off by 1.2-fold (0.08 log units), on the high side; the range from low to high includes it.
By their numbers in this assay, from the lowest: compound 1; then compound 3; then compound 2.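

In this assay, within the data shown here, the exchange of 2,3-dichlorophenyl for 3-acetamidophenyl on the amine nitrogen in the ring gives a 2.5-fold higher number from compound 1 to compound 3 (0.39 log units; beyond the scatter), the first step that isolates this position. The position therefore responds to the choice of aryl group, but the step is modest, and activity remains after both chlorines leave and a larger group with a hydrogen-bond donor and a hydrogen-bond acceptor enters. This single exchange changes several features at once, and no measurement bears on which of them accounts for the step.

The compounds shown leave open whether a single chlorine, a free amine or a carboxylic acid on this aryl ring would move the number further in either direction, and so how much of the step belongs to the loss of chlorine and how much to the acetamido group. They also leave open whether the same exchange would give a step of similar size with other groups on the rest of the molecule.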